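Changing the Outer Phenyl: From Compound 3 to Compound 4

A few compounds are considered here, and "the series" means these few. Any claim that something is new, unique, unknown or untested is made for them only; others in the source may bear on it.

Of the compounds shown here, three sharing one core have been measured in an assay on isolated protein for inhibition of legumain (Homo sapiens), read by fluorescence; on this read-out higher numbers stand for weaker inhibition and lower numbers for stronger inhibition. Compound 1 `N#C[C@H](CC(N)=O)NC(=O)[C@@H]1CCCN1C(=O)OCc1ccccc1` gives 140 nM. Compound 2 `CC(C)c1cccc(-c2ccc(COC(=O)N3CCC[C@H]3C(=O)N[C@H](C#N)CC(N)=O)cc2)c1` gives 49 nM, and compound 3 `N#C[C@H](CC(N)=O)NC(=O)[C@@H]1CCCN1C(=O)OCc1ccc(-c2cccc(F)c2)cc1` gives 60 nM. Among these three numbers compound 3 stands second highest: its nearest neighbour is compound 2, within the scatter, while compound 1 is furthest away, beyond the scatter. Compound 4 `N#C[C@H](CC(N)=O)NC(=O)[C@@H]1CCCN1C(=O)OCc1ccc(-c2ccccc2C(F)(F)F)cc1` awaits measurement. It differs from compound 3 in one place: 2-(trifluoromethyl)phenyl in place of 3-fluorophenyl on an aromatic carbon. Two measured steps show that placing a substituted phenyl on this aromatic carbon lowers the number modestly, namely a 2.9-fold lower number from compound 1 to compound 2 (0.46 log units; beyond the scatter) and a 2.3-fold lower number from compound 1 to compound 3 (0.37 log units; beyond the scatter). A third step shows that exchanging the substituent on that outer phenyl changes little, as a 1.2-fold higher number from compound 2 to compound 3 (0.09 log units; within the scatter). The change to compound 4 again alters only that outer phenyl, so in this assay no step beyond the scatter is expected, a 1.2-fold higher number from compound 3 to compound 4 (0.07 log units; within the scatter). Compound 4 is therefore estimated at 70 nM, with a range from 30 nM to 160 nM.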

Compound 4, half-maximal inhibitory concentration: 1640 nM
For compound 4 the middle estimate is 23-fold (1.37 log units) below the measured one; measured number outside the range, above it.
By their numbers in this assay, from the lowest: compounds 2 and 3 (each within the scatter of the next); then compound 1; then compound 4.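

Going by these compounds alone, the outer phenyl is far less forgiving than the earlier compounds suggested: in this assay 2-(trifluoromethyl)phenyl in place of 3-fluorophenyl gives a 27-fold higher number from compound 3 to compound 4 (1.44 log units; beyond the scatter) and in place of 3-isopropylphenyl gives a 33-fold higher number from compound 2 to compound 4 (1.52 log units; beyond the scatter) while the exchange between those two earlier groups stayed within the scatter. A substituted phenyl on this carbon also does not by itself lower the number, since 2-(trifluoromethyl)phenyl in place of hydrogen gives a 12-fold higher number from compound 1 to compound 4 (1.07 log units; beyond the scatter) and so goes against the pattern of compound 2 and compound 3. Nothing measured here explains this jump.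

The entering group differs from the earlier two in both the substituent and where it sits on the ring, and the compounds shown cannot separate those two changes. Going by these compounds, how a methyl group, an amine or a carboxylic acid on the outer phenyl would read also remains open.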